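The compounds below may be only part of what the source reports. "The series", "measured", "known", "first", "only" and "open" are said of these compounds alone.

Measured so far:
- compound 1 `CCOC(=O)C(=O)Nc1cccc(N(C)C)c1C#N`: 4.2 mg/kg
- compound 2 `CCOC(=O)C(=O)Nc1cccc(C(=O)OC)c1C#N`: 0.8 mg/kg

In a functional assay on the whole organism with Rattus norvegicus as the target (a higher number here means that more compound is needed for the effect, a lower number that less compound is needed), compound 1 gives 4.2 mg/kg, the highest of the two numbers shown. Compound 2 gives 0.8 mg/kg, reached by a 5.3-fold lower number from compound 1 to compound 2 (0.72 log units; beyond the scatter).

Compound 3 `CCOC(=O)C(=O)Nc1cccc(F)c1C#N` differs from compound 1 by fluoro in place of dimethylamino on an aromatic carbon.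

For the measured compounds named here, the one step that bears on this change is the same departure of dimethylamino seen from compound 1 to compound 2, which lowered the number beyond the scatter. Fluoro is a different entering group, so a smaller shift downward is expected, roughly a 2.1-fold lower number from compound 1 to compound 3 (0.32 log units; beyond the scatter). Compound 3 is therefore estimated to give 2 mg/kg, with a range from 0.7 mg/kg to 6 mg/kg.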

Compound 3, dose for half-maximal effect: 59 mg/kg
The estimate for compound 3 lay 30-fold (1.47 log units) below the measured number; measured number outside the range, above it.
By their numbers in this assay, from the lowest: compound 2; then compound 1; then compound 3.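

Fluoro on this aromatic carbon, ortho to the cyano group, gives the highest number of the three compounds, with a 14-fold higher number from compound 1 to compound 3 (1.15 log units; beyond the scatter) and a 74-fold higher number from compound 2 to compound 3 (1.87 log units; beyond the scatter) for the same position. Losing dimethylamino therefore does not by itself lower the number: the result depends on the group that enters, and the change can move the number in either direction. Methoxycarbonyl and fluoro, both replacing dimethylamino, land on opposite sides of compound 1.

Going by these compounds, whether a carboxylic acid, a primary amine or a methyl group here would fall nearer compound 2 or compound 3 remains open. No measurement shown accounts for the differences among these groups.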